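The source may hold more compounds than are shown below. What is called first, only, known or untested is meant among the compounds shown, and "the series" means these compounds.

Measured in an ADME assay on HEK293 cells (Homo sapiens) for inhibition, read by MTT assay, with a stated time of 48 h, tested at 25 uM; on this read-out lower numbers stand for less inhibition and higher numbers for more inhibition at the one concentration tested (going by the name of the read-out):
- compound 1 `COc1ccccc1-n1cc(COc2ccc3c(c2)CCC3)nn1`: 19.8%
- compound 3 `Fc1ccccc1-n1cc(COc2ccc3c(c2)CCC3)nn1`: 21%
- compound 2 `Clc1ccc(-n2cc(COc3ccc4c(c3)CCC4)nn2)cc1`: "not determined" (no result reported)

In this assay compound 3 holds the higher of the two numbers, and compound 1 gives the only other one. Among the measured compounds shown here, the sole measured step, a number 1.2 percentage points higher from compound 1 to compound 3 (within the scatter), lies within the scatter, so the two compounds cannot be told apart on this read-out.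

Compound 4 `COc1ccc(-n2cc(COc3ccc4c(c3)CCC4)nn2)cc1` differs from compound 3 at the aromatic nitrogen: 4-methoxyphenyl in place of 2-fluorophenyl on an aromatic nitrogen. For the measured compounds named here, no measured step covers a 4-methoxyphenyl; the nearest comparison is the fluoro-for-methoxy exchange, which left the number unchanged within scatter. The step from compound 3 to compound 4 is therefore expected to be a number 1 percentage points lower from compound 3 to compound 4 (within the scatter), within the scatter. Compound 4 is estimated at 20%, with a range of 9% to 32%.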

Compound 4, a percentage reported as inhibition, at one concentration (the size of the read-out at that concentration, not a potency): 21.1%
Compound 4: the middle estimate sits 1.1 percentage points below what was measured; measured number inside the range.
By their numbers in this assay, from the lowest: compounds 1, 3 and 4 (each within the scatter of the next).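

In this assay, 4-methoxyphenyl in place of 2-fluorophenyl on the aromatic nitrogen gives a number 0.1 percentage points higher from compound 3 to compound 4 (within the scatter), and 4-methoxyphenyl in place of 2-methoxyphenyl gives a number 1.3 percentage points higher from compound 1 to compound 4 (within the scatter). The earlier pair varied only the group on the 2-position of the phenyl; these steps add a change in where the methoxy sits on the phenyl, and the number still stays within the scatter. Nothing available accounts for this flat read-out.

From the compounds shown here alone, whether an amine or a carboxylic acid on the phenyl would move the number beyond the scatter remains open.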